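This account rests on a few compounds, and the source may have more. Where it says the series, first, only, none or still open, it means among the compounds named here.

Measured compounds in a functional assay on HT-29 cells (Homo sapiens) for inhibition, read by MTT assay, with a stated time of 2 days; a lower number here means a stronger inhibitor of growth, a higher number a weaker inhibitor of growth:

Compound 1 `O=C(Nn1c(-c2cccc([N+](=O)[O-])c2)nc2c(-c3ccc(Cl)cc3)n[nH]c2c1=O)c1ccccc1` gives 18500 nM.
Compound 2 `CCCCCc1nc2c(-c3ccc(Cl)cc3)n[nH]c2c(=O)n1NC(=O)c1cccc(C)c1` gives 5370 nM.
Compound 3 `Cc1cccc(C(=O)Nn2c(CC3CCCCC3)nc3c(-c4ccc(Cl)cc4)n[nH]c3c2=O)c1` gives 440 nM.

Compound 3 stands lowest of the three in this assay: the nearest is compound 2, whose number is higher by a step that lies beyond the scatter, and compound 1 lies higher still. Among the compounds with values here, the one single-point step among the measured compounds, a 12-fold lower number from compound 2 to compound 3 (1.09 log units; beyond the scatter), concerns the group on the saturated chain carbon bound to the shared core, not the amide end.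

Compound 4 `CC(C)(C)c1ccc(C(=O)Nn2c(CC3CCCCC3)nc3c(-c4ccc(Cl)cc4)n[nH]c3c2=O)cc1` differs from compound 3 elsewhere: 4-(tert-butyl)phenyl in place of 3-methylphenyl on a carbonyl carbon. No measured pair isolates a change at this carbonyl, so nothing among the shown numbers speaks for or against a shift here; the measured step from compound 2 to compound 3 does not bear on it. Without such evidence, the expectation is no step beyond the scatter, and compound 4 is estimated at 450 nM, within 150 nM to 1500 nM, which means an expected step of a 1.0-fold higher number from compound 3 to compound 4 (0.01 log units; within the scatter).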

Compound 4, concentration for 50% growth inhibition: 1060 nM
Estimate against measurement, compound 4: 2.4-fold (0.37 log units) below; measured number inside the range.
By their numbers in this assay, from the lowest: compound 3; then compound 4; then compound 2; then compound 1.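

In this assay, the group on the carbonyl carbon turns out not to be a silent position: 4-(tert-butyl)phenyl in place of 3-methylphenyl gives a 2.4-fold higher number from compound 3 to compound 4 (0.38 log units; beyond the scatter). This is the only pair shown that changes this end of the molecule while the rest stays the same, and the step is beyond the scatter yet modest beside a 12-fold lower number from compound 2 to compound 3 (1.09 log units; beyond the scatter) at the chain end. No measurement shown offers a reason for this step.

The change alters both the alkyl group on the phenyl ring and its place on that ring, so the compounds shown cannot tell which of the two matters. Going by these compounds, a 4-methylphenyl or a 3-(tert-butyl)phenyl group on this carbonyl carbon would separate the two, and how an amine or a carboxylic acid on the phenyl ring would read here stays open.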